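A few compounds are considered here, and "the series" means these few. Any claim that something is new, unique, unknown or untested is made for them only; others in the source may bear on it.

Measured compounds:
- Compound 1 `COc1ccc(-c2cc(=O)c3c(OC)cc(OC)cc3n2C)cc1`: in an ADME assay on BJ cells (Homo sapiens) for antiproliferative activity, with a stated time of 72 h (on this read-out lower numbers stand for an effect already at smaller amounts and higher numbers for an effect only at larger amounts of compound), compound 1 gives 68000 nM.
- Compound 2 `COc1ccc(-c2cc(=O)c3c(OC)cc(OC)cc3n2S(=O)(=O)c2ccc(C=O)cc2)cc1`: compound 2 gives > 34400 nM, which is a limit of the assay rather than a number.
- Compound 3 `COc1ccc(-c2cc(=O)c3c(OC)cc(OC)cc3n2S(=O)(=O)c2ccc([N+](=O)[O-])cc2)cc1`: compound 3 gives > 29300 nM, again a limit and not a number.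

Compound 3 therefore stands at the limit of > 29300 nM in this assay, at which 1 of the 3 values shown sits. Compound 2 sits at the limit of > 34400 nM in this assay, at which 1 of the 3 values shown sits. Compound 4 `COc1ccc(-c2cc(=O)c3c(OC)cc(OC)cc3n2S(=O)(=O)c2ccc(C#N)cc2)cc1` differs from compound 3 in one place: cyano in place of nitro on an aromatic carbon. Among the compounds with values here, two measured steps bear on this change, a step that the limit leaves unreadable from compound 1 to compound 2 and a step that the two limits leave unreadable from compound 2 to compound 3, and both are left unreadable by the limits, so no size or direction can be drawn from them. Compound 4 is thus expected to land close to where compound 3 sits, with a step that the limit leaves unreadable from compound 3 to compound 4. The estimate for compound 4 is 35000 nM, within the range 15000 nM to 80000 nM, most likely again reported only as a limit.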

Compound 4, half-maximal effective concentration: > 17200 nM
Compound 4 was reported as a limit; the forecaster's own chance of this, stated with the estimate: 70%; the middle value does not contradict the limit.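

Compound 4 is reported only as a limit and not as a number, so its steps from compound 1, compound 2 and compound 3 cannot be read. The compounds shown leave open how far compound 2, compound 3 and compound 4 truly lie from compound 1 or from one another.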